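The compounds below may be only part of what the source reports. "The series", "measured", "known", "first", "only" and "open" are said of these compounds alone.

Compound 1, with the structure `O=C(CCN1CCCCC1)N1CCC2(N3CCCCC3)CC(c3ccccc3)C1C(c1ccccc1)C2`, was tested in an ADME assay on L6 cells (Rattus norvegicus) for cytotoxicity (on this read-out lower numbers stand for stronger inhibition and higher numbers for weaker inhibition), where it gives 63900 nM. This is the highest of the two numbers available, the other coming from compound 2, structure `c1ccc(C2CC3(N4CCCC4)CCN(CCCN4CCCCC4)C2C(c2ccccc2)C3)cc1`, which in this assay gives 28700 nM, a separation beyond the usual scatter. Compound 3, structure `c1ccc(C2CC3(N4CCCCC4)CCN(CCN4CCCC4)C2C(c2ccccc2)C3)cc1`, has not yet been measured. It differs from compound 1 in one place: 2-(pyrrolidin-1-yl)ethyl in place of (2-(piperidin-1-yl)ethyl)carbonyl on an amine nitrogen in a ring. Compound 2 likewise carries a chain without a carbonyl on an amine nitrogen in a ring, and its value of 28700 nM sits below that of compound 1. On that basis the step of a 2.1-fold lower number from compound 1 to compound 3 (0.33 log units; beyond the scatter) is expected to go toward a lower number, of moderate size and probably beyond the scatter. Compound 3 is therefore estimated to give 30000 nM, within a range from 12000 nM to 75000 nM.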

Compound 3, half-maximal inhibitory concentration: 156000 nM
Compound 3: the middle estimate sits 5.2-fold (0.72 log units) below what was measured; measured number outside the range, above it.
By their numbers in this assay, from the lowest: compound 2; then compound 1; then compound 3.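

Among the compounds shown here, this pair gives the first comparison in which only one place changes: on the amine nitrogen in a ring, 2-(pyrrolidin-1-yl)ethyl replaces (2-(piperidin-1-yl)ethyl)carbonyl, and in this assay this gives a 2.4-fold higher number from compound 1 to compound 3 (0.39 log units; beyond the scatter). At this position, then, a chain without the carbonyl does not bring a lower number on the shared core; here it brings weaker inhibition, a modest step beyond the scatter. No measurement shown here accounts for the direction of this step.

The change removes the carbonyl and also swaps a six-membered ring for a five-membered one, so the step cannot be assigned to either alone. A 2-(piperidin-1-yl)ethyl group on the same nitrogen, or a (2-(pyrrolidin-1-yl)ethyl)carbonyl group, would change only one of these two features relative to compound 1 or compound 3.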